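A few compounds are considered here, and "the series" means these few. Any claim that something is new, unique, unknown or untested is made for them only; others in the source may bear on it.

In a toxicity assay on HepG2 2.2.15 cells (Homo sapiens) for cytotoxicity, read by CellTiter-Glo (on this read-out higher numbers stand for lower toxicity in this test and lower numbers for higher toxicity in this test), compound 1 `O=C1CC(c2cnco2)CN1c1cnn2c1CN(C(=O)Nc1cc(F)c(F)c(F)c1)C(C1CC1)C2` gives 139000 nM, and compound 2 `O=C1CC(c2ccc(F)cc2)CN1c1cnn2c1CN(C(=O)Nc1cc(F)c(F)c(F)c1)C(C1CC1)C2` gives 32100 nM. Compound 3 `O=C1CC(c2ncccn2)CN1c1cnn2c1CN(C(=O)Nc1cc(F)c(F)c(F)c1)C(C1CC1)C2` stands at > 200000 nM, which is a limit of the assay and not a number. Compound 4 `O=C1CC(c2ccccc2)CN1c1cnn2c1CN(C(=O)Nc1cc(F)c(F)c(F)c1)C(C1CC1)C2` has phenyl in place of pyrimidin-2-yl on a saturated ring carbon. The closest measured change is an at least 6.2-fold higher number from compound 2 to compound 3 (0.79 log units; beyond the scatter), where pyrimidin-2-yl replaces 4-fluorophenyl. Also relevant is a 4.3-fold lower number from compound 1 to compound 2 (0.64 log units; beyond the scatter), where 4-fluorophenyl replaces 1,3-oxazol-5-yl, whereas an at least 1.4-fold higher number from compound 1 to compound 3 (0.15 log units; that floor lies within the scatter) joins the two compounds without a carbon-only ring. Compound 4 therefore returns to a carbon-only ring, and a modest or larger fall in the number is expected, with an estimated at least 4.4-fold lower number from compound 3 to compound 4 (0.64 log units; beyond the scatter). For compound 4 the expected value is 45000 nM, within an estimated range of 20000 nM to 110000 nM.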

Compound 4, half-maximal cytotoxic concentration: 12800 nM
For compound 4 the middle estimate is 3.5-fold (0.55 log units) above the measured one, outside the stated range (below it).
By their numbers in this assay, from the lowest: compound 4; then compound 2; then compound 1. At a limit, above all of these: compound 3.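

In this assay the plain phenyl ring on this saturated ring carbon gives the lowest number of the set, and the step of an at least 15-fold lower number from compound 3 to compound 4 (1.19 log units; beyond the scatter) is only a floor, set by a limit of the assay for compound 3: the limit of > 200000 nM in this assay, at which 1 of the 4 values shown sits. The fluoro group also counts, with hydrogen in its place on an aromatic carbon giving a 2.5-fold lower number from compound 2 to compound 4 (0.40 log units; beyond the scatter) in a modest step. Against the oxazole, the change gives an 11-fold lower number from compound 1 to compound 4 (1.04 log units; beyond the scatter) in a large step.

The compounds shown leave open where a pyridin-2-yl ring would fall on this carbon. They also leave open how a saturated amine or a carboxylic acid would read there.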